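Removing the Pyridylethyl Arm from Compound 2

The source may hold more compounds than are shown below. What is called first, only, known or untested is meant among the compounds shown, and "the series" means these compounds.

Of the compounds shown here, two have been measured in an in vitro functional assay on Sf9 cells for antagonist activity at histamine H2 receptor (Homo sapiens); on this read-out higher numbers stand for higher potency (the scale is a negative logarithm) and lower numbers for lower potency. Compound 1 `N#C/N=C(\NCCCCc1ccccc1)NCCCCc1c[nH]cn1` gives 5.03 in this assay, and compound 2 `N#C/N=C(/NCCCCc1c[nH]cn1)NCCCc1ccccn1` gives 5.48. For the measured compounds named here, the single measured step, a number 0.45 log units higher from compound 1 to compound 2 (beyond the scatter), leaves compound 2 as the higher of the two numbers, with compound 1 as its only neighbour.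

Compound 3 `CC(C)CN/C(=N\C#N)NCCCCc1c[nH]cn1` is the compound awaiting measurement. It differs from compound 2 in one respect: isopropyl in place of 2-(pyridin-2-yl)ethyl on a saturated chain carbon bound to an amine nitrogen. The six-membered aromatic ring with one hetero atom disappears altogether, and a short branched group takes its place on a saturated chain carbon bound to an amine nitrogen.

Going by the values given here, only one measured step bears on this change, and only loosely. The step of a number 0.45 log units higher from compound 1 to compound 2 (beyond the scatter) showed that pyridin-2-yl in place of benzyl, three bonds along the chain from an amine nitrogen, raised potency modestly. Among the compounds with values here, no measured step removes the aromatic ring entirely, so the size of the effect in this assay is uncertain, but losing the group that the earlier step favoured is expected to cost potency. The step of a number 0.48 log units lower from compound 2 to compound 3 (beyond the scatter) is therefore expected to be a modest fall. The estimate for compound 3 is 5, expected to lie between 4.4 and 5.6.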

Compound 3, negative logarithm of the antagonist equilibrium constant: < 5
Compound 3: only a limit was reported; the forecaster's own chance of this, stated with the estimate: 10%; the middle value lies on the limit itself.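

In this assay compound 3 carries a limit rather than a number, < 5, and it is the only limit among the compounds shown: the limit of < 5 in this assay, at which 1 of the 3 values shown sits. Even so, the exchange of 2-(pyridin-2-yl)ethyl for isopropyl on a saturated chain carbon bound to an amine nitrogen can be read as a step, a number at least 0.48 log units lower from compound 2 to compound 3 (beyond the scatter), and this gives the first measured case in which the six-membered aromatic ring with one hetero atom is absent from this place, since the earlier step only replaced one ring-bearing group with another. The change therefore shows that, with the rest of the structure held constant, potency at this place does not survive this exchange intact, and the true size of the loss may be larger than the step prints.

The exchange removes the ring and shrinks the group from 8 heavy atoms to 3 at once, so the compounds shown cannot tell which of the two matters. Going by these compounds, a 2-cyclohexylethyl group or an unbranched hexyl chain at this place would begin to separate them, and whether either would match compound 2 remains open.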